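The source may report more compounds than this note shows. Statements on the series, on what has been measured and on what is new or still open speak of the compounds shown alone.

Compound 2 `CC#CC(=O)Nc1cccc(Nc2ncnc(Nc3ccc(C(=O)N4CCCCC4)cc3)n2)c1` carries the higher of the two numbers recorded so far in a functional assay on Ramos cells (Homo sapiens) for antiproliferative activity, read by CCK-8 assay, with a stated time of 24 h; on this read-out higher numbers stand for weaker inhibition and lower numbers for stronger inhibition: compound 2 gives 24400 nM, whereas compound 1 `C=CC(=O)Nc1cccc(Nc2ncnc(Nc3ccc(C(=O)N4CCCCC4)cc3)n2)c1` gives 6140 nM. Among the measured compounds shown here, the single measured step, a 4.0-fold higher number from compound 1 to compound 2 (0.60 log units; beyond the scatter), links a change of the group on the carbonyl carbon to a modest loss. Compound 3 `C/C=C/C(=O)Nc1cccc(Nc2ncnc(Nc3ccc(C(=O)N4CCCCC4)cc3)n2)c1` differs from compound 2 by prop-1-en-1-yl in place of prop-1-yn-1-yl on a carbonyl carbon. For the measured compounds named here, only the step from compound 1 to compound 2 bears on this change, and compound 3 stands between those two structures, keeping the prop-1-en-1-yl chain length of compound 2 but returning to a double bond as in the vinyl of compound 1. A modest step downward is therefore expected, a 2.7-fold lower number from compound 2 to compound 3 (0.43 log units; beyond the scatter), because a 4.0-fold higher number from compound 1 to compound 2 (0.60 log units; beyond the scatter) ran upward when the double bond was exchanged for a triple bond. Compound 3 is estimated at 9000 nM in this assay, with a range of 3500 nM to 25000 nM.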

Compound 3, half-maximal inhibitory concentration: 13200 nM
The estimate for compound 3 lay 1.5-fold (0.17 log units) below the measured number, and the stated range covers the measured number.
By their numbers in this assay, from the lowest: compound 1; then compounds 3 and 2 (each within the scatter of the next).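

Moving from the triple to the double bond in the three-carbon chain on the carbonyl carbon gives a 1.8-fold lower number from compound 2 to compound 3 (0.27 log units; within the scatter) in this assay, so this change of bond does not separate compound 2 from compound 3 on this read-out. With the double bond kept, prop-1-en-1-yl in place of vinyl gives a 2.1-fold higher number from compound 1 to compound 3 (0.33 log units; beyond the scatter) in this assay, showing that the difference from compound 1 does not depend on the triple bond and that compound 1 remains the strongest inhibitor of the three. No measurement given here accounts for these differences.

The three compounds leave open how a longer chain or an amine at the end of the prop-1-en-1-yl group would read in this assay. They also leave open whether the order seen here would hold with a different group in place of the shared core.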